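Moving a chlorine around the aryl ring of a piperazine amide

The source may report more compounds than this note shows. Statements on the series, on what has been measured and on what is new or still open speak of the compounds shown alone.

Compound 1 `COc1cccc(N2CCN(C(=O)c3oc(C(F)(F)F)nc3-c3cccc(F)c3)CC2)c1` gives "not active" (no number reported) in a functional assay on HL-60 cells (Homo sapiens) for inhibition, read by MTT assay, with a stated time of 72 h (on this read-out higher numbers stand for weaker inhibition and lower numbers for stronger inhibition), with no number attached. Compound 2 `Cc1nc(-c2ccccc2)c(C(=O)N2CCN(c3ccc(Cl)c(Cl)c3)CC2)o1` gives 124 nM in this assay, and this is the only numerical result the series offers, so compound 2 stands alone as the point of reference. Compound 3 `Cc1nc(-c2ccccc2)c(C(=O)N2CCN(c3cc(Cl)cc(Cl)c3)CC2)o1` is the not yet measured partner of compound 2; the two share every atom and differ in the arrangement described by 3,5-dichlorophenyl in place of 3,4-dichlorophenyl on an amine nitrogen in a ring. Among the compounds with values here, no measured pair of neighbours shows what such a change does here, so the size of the step is open. The account expects a 1.6-fold higher number from compound 2 to compound 3 (0.21 log units; within the scatter) to stay small, most likely no further than the usual scatter, with a mild lean towards weaker inhibition. Compound 3 is therefore estimated at 200 nM in this assay, within a range from 60 nM to 700 nM.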

Compound 3, half-maximal inhibitory concentration: 41.8 nM
Compound 3: the middle estimate sits 4.8-fold (0.68 log units) above what was measured; the whole stated range lies above it.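

In this assay, within the data shown here, replacing 3,4-dichlorophenyl with 3,5-dichlorophenyl on the ring amine nitrogen brings a 3.0-fold lower number from compound 2 to compound 3 (0.47 log units; beyond the scatter), the first measured step at this position. The two groups have the same heavy atoms and the same counts of hydrogen-bond donors and acceptors, so the arrangement of the two chlorines alone is enough to move the result beyond the scatter, towards stronger inhibition. Nothing given here accounts for this shift.

Compound 1 differs from compound 2 and compound 3 in more than one place, so it cannot be read against either of them and does not show how far the shift carries to other parts of the molecule. The compounds shown also leave open whether 3,5-dibromophenyl or 3,5-dimethylphenyl in the same place would match, exceed or lose the value of compound 3.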